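Swapping a thiadiazolyl sulfide for a methylpiperazine

The compounds below may be only part of what the source reports. "The series", "measured", "known", "first", "only" and "open" are said of these compounds alone.

Two compounds share a core and differ only in one group on a saturated chain carbon bound to a carbonyl carbon. Compound 1 `Cn1c(-c2ccc(NC(=O)CCl)cc2)nc(-c2ccccc2)c1-c1ccccc1` carries chloro there, and in a functional assay on HT-29 cells (Homo sapiens) for cytotoxicity, read by MTT assay, with a stated time of 24 h, tested at 6.4 ug/mL (on this read-out lower numbers stand for a weaker effect and higher numbers for a stronger effect at the one concentration tested), compound 1 gives 15.1%. Compound 2 `Cc1nnc(SCC(=O)Nc2ccc(-c3nc(-c4ccccc4)c(-c4ccccc4)n3C)cc2)s1` carries (5-methyl-1,3,4-thiadiazol-2-yl)sulfanyl instead, and compound 2 gives 73%; the change is a number 57.9 percentage points higher from compound 1 to compound 2 (beyond the scatter). Compound 2 therefore stands highest of the two numbers, with compound 1 the nearest and well below it.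

Compound 3 `CN1CCN(CC(=O)Nc2ccc(-c3nc(-c4ccccc4)c(-c4ccccc4)n3C)cc2)CC1` is not yet measured. It differs from compound 2 in the change (4-methylpiperazin-1-yl in place of (5-methyl-1,3,4-thiadiazol-2-yl)sulfanyl on a saturated chain carbon bound to a carbonyl carbon). Going by the values given here, the only measured step that bears on this position is a number 57.9 percentage points higher from compound 1 to compound 2 (beyond the scatter), which shows that what sits there can move the number a great deal. Among the compounds with values here, no measured pair shows a 4-methylpiperazin-1-yl group, so the direction for compound 3 is uncertain, and a wide range is appropriate. The estimate for compound 3 is 45%, with a range from 15% to 75%, which would mean an expected step of a number 28 percentage points lower from compound 2 to compound 3 (beyond the scatter).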

Compound 3, a percentage reported as activity, at one concentration (the size of the read-out at that concentration, not a potency): 28.8%
For compound 3 the middle estimate is 16.2 percentage points above the measured one; measured number inside the range.
By their numbers in this assay, from the lowest: compound 1; then compound 3; then compound 2.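

In this assay the group on the saturated chain carbon bound to a carbonyl carbon matters even when its size by heavy-atom count stays the same: the step is a number 44.2 percentage points lower from compound 2 to compound 3 (beyond the scatter) and comes with a change from 5-methyl-1,3,4-thiadiazol-2-yl joined through sulfur to 4-methylpiperazin-1-yl, so heavy-atom count alone does not set the number here. Against chloro, the 4-methylpiperazin-1-yl group still gives a number 13.7 percentage points higher from compound 1 to compound 3 (beyond the scatter) and this gain is only modest, which means that replacing chloro with a larger group does not by itself bring the large gain seen with the (5-methyl-1,3,4-thiadiazol-2-yl)sulfanyl group. Nothing measured here explains why these two groups differ.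

The step from compound 2 to compound 3 changes the sulfur link and the ring together, so the compounds shown cannot separate the two, and a phenylsulfanyl group or a plain 1,3,4-thiadiazole joined without sulfur would be needed to pull them apart. On these data alone, it also remains open how other amines would sit, such as morpholine, dimethylamine or piperazine without its methyl group.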